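This account rests on a few compounds, and the source may have more. Where it says the series, first, only, none or still open, it means among the compounds named here.

Working notes on the series. The compounds share one core and differ in the group on a saturated chain carbon bound to an oxygen on an aromatic ring. In a functional assay on B16 cells (Mus musculus) for antiproliferative activity, read by MTT assay, with a stated time of 24 h (on this read-out higher numbers stand for weaker inhibition and lower numbers for stronger inhibition), compound 1 (`COc1cc(OC)c(-c2coc3cc(OCc4ccc(F)cc4)ccc3c2=O)cc1OC`) gives 1120 nM, compound 2 (`COc1cc(OC)c(-c2coc3cc(OCc4ccccc4C#N)ccc3c2=O)cc1OC`) gives 2140 nM and compound 3 (`COc1cc(OC)c(-c2coc3cc(OCc4ccc(Cl)cc4)ccc3c2=O)cc1OC`) gives 2400 nM. Compound 3 thus sits level with compound 2 and above compound 1 on these numbers.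

The next member is compound 4 (`COc1cc(OC)c(-c2coc3cc(OCc4cccc(Br)c4)ccc3c2=O)cc1OC`), with 3-bromophenyl in place of 4-chlorophenyl at that same place: 3-bromophenyl in place of 4-chlorophenyl on a saturated chain carbon bound to an oxygen on an aromatic ring. For the measured compounds named here, no measured compound carries 3-bromophenyl, so the evidence is indirect and comes only from other exchanges of this group. Those are a 1.1-fold higher number from compound 2 to compound 3 (0.05 log units; within the scatter) and a 1.9-fold higher number from compound 1 to compound 2 (0.28 log units; within the scatter), both small, and a 2.1-fold higher number from compound 1 to compound 3 (0.33 log units; beyond the scatter), which is modest and the only one beyond the scatter. Going by the values given here, with steps of this size as the sole guide, no step beyond the scatter is expected in this assay, and no direction can be firmly assigned. The estimate is a 1.2-fold lower number from compound 3 to compound 4 (0.08 log units; within the scatter), an expected shift that stays inside the scatter. In this assay the expected value for compound 4 is 2000 nM, with an estimated range from 900 nM to 4500 nM.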

Compound 4, half-maximal inhibitory concentration: 4400 nM
Compound 4: middle estimate off by 2.2-fold (0.34 log units), on the low side, and the stated range covers the measured number.
By their numbers in this assay, from the lowest: compounds 1, 2, 3 and 4 (each within the scatter of the next, the first and the last beyond it).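

In this assay, the exchange to 3-bromophenyl on a saturated chain carbon bound to an oxygen on an aromatic ring gives a 1.8-fold higher number from compound 3 to compound 4 (0.26 log units; within the scatter), so compound 4 cannot be told apart from compound 3 and the swap of 4-chlorophenyl for 3-bromophenyl has no readable effect at this place. The new group does separate from the other two: the comparison with the nitrile-bearing member reads a 2.1-fold higher number from compound 2 to compound 4 (0.31 log units; beyond the scatter), and the comparison with the fluoro member reads a 3.9-fold higher number from compound 1 to compound 4 (0.59 log units; beyond the scatter), the latter being the largest step yet seen at this position. Even so, both of these steps are only modest, so across four aryl groups of equal heavy-atom count this place has so far produced no large change in the number.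

The step from compound 3 to compound 4 alters both the halogen and its place on the ring, so only 4-bromophenyl or 3-chlorophenyl could separate those two changes, while an amine, a carboxylic acid or a longer chain at this position remains untested in the compounds shown. Nothing in hand gives any measured reason for the differences seen at this position.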